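A few compounds are considered here, and "the series" means these few. Any claim that something is new, unique, unknown or untested is made for them only; others in the source may bear on it.

Measured so far:
compound 1 `O=C(Nc1ccc([N+](=O)[O-])c(Cl)c1)c1cc(Cl)ccc1O`: < 1 ug/mL (a limit)
compound 2 `O=C(Nc1ccc(C(F)(F)F)cc1)c1cc(Br)ccc1O`: < 1 ug/mL (a limit)
compound 3 `O=C(Nc1ccc(C(F)(F)F)c(Cl)c1)c1cc(Br)ccc1O`: < 1 ug/mL (a limit)

All three results come from a physicochemical assay for solubility; a higher number here means a more soluble compound, a lower number a less soluble compound. In this assay compound 3 gives < 1 ug/mL, which is a limit of the assay and not a number. It therefore has no exact place in the series, and the overall picture is the limit of < 1 ug/mL in this assay, at which 3 of the 3 values shown sit.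

The next compound is compound 4 `O=C(Nc1ccc([N+](=O)[O-])c(Cl)c1)c1cc(Br)ccc1O`, which has nitro in place of trifluoromethyl on an aromatic carbon.

Among the compounds with values here, only one measured step exists, a step that the two limits leave unreadable from compound 2 to compound 3. It is a different change, chloro in place of hydrogen, so it offers no size to carry over. The closest guide is compound 1, which also carries a nitro group and gives < 1 ug/mL, again a limit of the assay. With every result at this limit, there is no measured basis for expecting a step beyond the usual scatter in this assay, in either direction. The expected step is a step that the limit leaves unreadable from compound 3 to compound 4, and this is a rough estimate. Most likely the assay will again report only a limit. For compound 4 the estimated value is 0.6 ug/mL, with an expected range from 0.2 ug/mL to 1.5 ug/mL.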

Compound 4, solubility: < 1 ug/mL
Compound 4: no number, only a limit; the forecaster's own chance of this, stated with the estimate: 85%; the middle value lies beyond the limit too.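

In this assay compound 4 gives < 1 ug/mL, which is a limit of the assay and not a number. The steps to compound 4 from compound 3 and from compound 1 cannot be read, and the whole series sits at one point: the limit of < 1 ug/mL in this assay, at which 4 of the 4 values shown sit. The compounds shown leave open how soluble each one actually is, and whether swapping trifluoromethyl for nitro or chloro for bromo makes any difference.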